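Halogen swap at the same aromatic carbon: growth-inhibition notes

The source may report more compounds than this note shows. Statements on the series, on what has been measured and on what is new or still open speak of the compounds shown alone.

Measured compounds:
Compound 1 `CCN(CC)CN1C(=O)/C(=N\c2nc3ccc(C)cc3s2)c2ccccc21` — 20400 nM
Compound 2 `CCN(CC)CN1C(=O)/C(=N\c2nc3ccc(C)cc3s2)c2c(Br)cccc21` — 16100 nM
Compound 3 `Cc1ccc2nc(/N=C3\C(=O)N(CN(C)C)c4cccc(Br)c43)sc2c1` — 21800 nM

In an ADME assay on MCF-10A cells (Homo sapiens) for cytotoxicity, read by sulforhodamine B assay, with a stated time of 48 h (on this read-out lower numbers stand for stronger inhibition of growth and higher numbers for weaker inhibition of growth), the three compounds give numbers close together. Compound 2 carries the lowest of the three, yet the step of a 1.3-fold lower number from compound 1 to compound 2 (0.10 log units; within the scatter) and the step of a 1.4-fold higher number from compound 2 to compound 3 (0.13 log units; within the scatter) both lie within the scatter, so the three cannot be told apart on these data. Bromo in place of hydrogen on an aromatic carbon and dimethylamino in place of diethylamino on the saturated chain carbon bound to the amide-type nitrogen in a ring each left the read-out essentially unchanged.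

Compound 4 `CCN(CC)CN1C(=O)/C(=N\c2nc3ccc(C)cc3s2)c2c(Cl)cccc21` has not yet been measured. It differs from compound 2 by chloro in place of bromo on an aromatic carbon. For the measured compounds named here, no measured step exchanges one halogen for another; the only step at this position, a 1.3-fold lower number from compound 1 to compound 2 (0.10 log units; within the scatter), shows that bromo versus hydrogen made no difference beyond the scatter, and no other measured step bears on the change. The data therefore give no ground to expect a shift beyond the scatter in either direction.

Compound 4 is accordingly expected to give 16000 nM in this assay, with a range from 8000 nM to 32000 nM. The expected step of a 1.0-fold lower number from compound 2 to compound 4 (0.00 log units; within the scatter) is within the scatter.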

Compound 4, concentration for 50% growth inhibition: 43900 nM
Beside the measured number, compound 4's estimate is 2.7-fold (0.44 log units) below it; the measured number lies above the stated range.
By their numbers in this assay, from the lowest: compounds 2, 1, 3 and 4 (each within the scatter of the next, the first and the last beyond it).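

The exchange of halogens at this aromatic carbon is not neutral in this assay: a 2.7-fold higher number from compound 2 to compound 4 (0.44 log units; beyond the scatter), and against the unsubstituted parent there is a 2.2-fold higher number from compound 1 to compound 4 (0.33 log units; beyond the scatter). The earlier compounds shown here showed only that bromo and hydrogen could not be told apart here, whereas chloro separates from both, so this position does respond to what it carries, and the read-out does not rise or fall simply with the presence of a halogen. Compound 4, with the higher number, shows weaker inhibition of growth than either compound 1 or compound 2, and nothing available accounts for this difference between chloro and bromo.

As far as these compounds go, whether fluoro, iodo, methyl or methoxy on the same aromatic carbon would follow chloro or stay with bromo and hydrogen remains open, and with only these groups the separation of chloro rests on a single pair of steps. Also open, from the compounds shown here alone, is whether chloro would give a comparable step with dimethylamino in place of diethylamino on the chain, or with a longer amine there.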